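From 3-hydroxyphenyl to 4-hydroxyphenyl on the shared core

This account rests on a few compounds, and the source may have more. Where it says the series, first, only, none or still open, it means among the compounds named here.

Compound 1 `C#CCSc1nc(Nc2ccc(C)cc2)c2ccncc2n1`: 6170 nM
Compound 2 `C#CCSc1nc(Nc2ccc([N+](=O)[O-])cc2)c2ccncc2n1`: > 80000 nM, a limit of the assay
Compound 3 `C#CCSc1nc(Nc2cccc(O)c2)c2ccncc2n1`: 29500 nM

In a functional assay on HepG2 cells (Homo sapiens) for inhibition, read by MTT assay, with a stated time of 72 h (a higher number here means a weaker inhibitor, a lower number a stronger inhibitor), compound 3 holds the higher of the two actual numbers, with compound 1 nearest at 6170 nM. Compound 4 `C#CCSc1nc(Nc2ccc(O)cc2)c2ccncc2n1` remains unmeasured and has 4-hydroxyphenyl in place of 3-hydroxyphenyl on a nitrogen on an aromatic ring. For the measured compounds named here, two measured steps bear on this change, although neither is the same swap: a 4.8-fold higher number from compound 1 to compound 3 (0.68 log units; beyond the scatter) is modest, and an at least 12-fold higher number from compound 1 to compound 2 (1.11 log units; beyond the scatter) is large. Neither shows what this swap alone does, so no step beyond the scatter is expected. The expected result is a 1.3-fold lower number from compound 3 to compound 4 (0.13 log units; within the scatter). For compound 4 the estimated value is 22000 nM, with an expected range of 7000 nM to 70000 nM.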

Compound 4, half-maximal inhibitory concentration: > 80000 nM
Compound 4: no number, only a limit; the forecaster's own chance of this, stated with the estimate: 12%; middle value at least 3.6-fold (0.56 log units) from the limit.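

Moving the hydroxy group on this ring matters: 4-hydroxyphenyl in place of 3-hydroxyphenyl on a nitrogen on an aromatic ring brings an at least 2.7-fold higher number from compound 3 to compound 4 (0.43 log units; beyond the scatter). Exchanging the methyl group for a hydroxy group brings an at least 12-fold higher number from compound 1 to compound 4 (1.11 log units; beyond the scatter), so the methyl of compound 1 is not replaced by this group without a large loss in this assay. The step between compound 2 and compound 4 cannot be read, because each value is only a limit: the limit of > 80000 nM in this assay, at which 2 of the 4 values shown sit.

Going by these compounds, what an amine or a methoxy group would give in place of this hydroxy stays open. On these data alone, the actual value of compound 4 also remains unknown.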